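A few compounds are considered here, and "the series" means these few. Any claim that something is new, unique, unknown or untested is made for them only; others in the source may bear on it.

Compound 1 `CN(C)CCCCCn1c2c(c3ccccc31)C(=O)c1c[n+]([O-])c3ccccc3c1C2=O`: 470 nM
Compound 2 `O=C1c2c[n+]([O-])c3ccccc3c2C(=O)c2c1c1ccccc1n2Cc1cn(C[C@H](O)CO)nn1`: 400 nM
Compound 3 `O=C1c2c[n+]([O-])c3ccccc3c2C(=O)c2c1c1ccccc1n2Cc1cn(CC(O)CO)nn1`: 250 nM

In a functional assay on HCT-116 cells (Homo sapiens) for cytotoxicity, read by MTT assay, with a stated time of 72 h (on this read-out higher numbers stand for weaker inhibition and lower numbers for stronger inhibition), compound 2 stands second highest of the three numbers: its nearest neighbour is compound 1, a step of a 1.2-fold lower number from compound 1 to compound 2 (0.07 log units; within the scatter), and its furthest is compound 3, a step of a 1.6-fold lower number from compound 2 to compound 3 (0.20 log units; within the scatter). Compound 4 `O=C1c2c[n+]([O-])c3ccccc3c2C(=O)c2c1c1ccccc1n2CCCN1CCC(O)CC1` differs from compound 2 by 2-(4-hydroxypiperidin-1-yl)ethyl in place of 1-(2,3-dihydroxypropyl)-1H-1,2,3-triazol-4-yl on a saturated chain carbon bound to an aromatic nitrogen. The measured steps that bear on this change are a 1.2-fold lower number from compound 1 to compound 2 (0.07 log units; within the scatter) and a 1.9-fold lower number from compound 1 to compound 3 (0.27 log units; within the scatter), both within the scatter, and compound 4 returns to a chain like that of compound 1 rather than the triazole of compound 2. No step beyond the scatter is therefore expected. Compound 4 is estimated at 450 nM, with a range of 200 nM to 1000 nM, which means an expected step of a 1.1-fold higher number from compound 2 to compound 4 (0.05 log units; within the scatter).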

Compound 4, half-maximal inhibitory concentration: 190 nM
Beside the measured number, compound 4's estimate is 2.4-fold (0.37 log units) above it; measured number outside the range, below it.
By their numbers in this assay, from the lowest: compounds 4, 3, 2 and 1 (each within the scatter of the next, the first and the last beyond it).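

In this assay, within the data shown here, the 3-(4-hydroxypiperidin-1-yl)propyl chain gives the first steps beyond the scatter at this position, both modest (a 2.5-fold lower number from compound 1 to compound 4 (0.39 log units; beyond the scatter); a 2.1-fold lower number from compound 2 to compound 4 (0.32 log units; beyond the scatter)). The exchange of the triazole group stays within the scatter when read from the other triazole compound (a 1.3-fold lower number from compound 3 to compound 4 (0.12 log units; within the scatter)), so its reading depends on which of the two is taken, and these differ in one respect only: the fact that one of compounds 2 and 3 is drawn with a defined configuration and the other without, at the place where they differ. The compounds shown leave open whether the lower numbers follow the hydroxyl group, the ring or the chain. A piperidine without the hydroxyl, a morpholine or a dimethylamino group on the same propyl chain would separate these.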